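Carboxy to chloro on the pyridine of compound 2

This account rests on a few compounds, and the source may have more. Where it says the series, first, only, none or still open, it means among the compounds named here.

In an ADME assay on PBMC cells (Homo sapiens) for cytotoxicity (on this read-out lower numbers stand for higher toxicity in this test and higher numbers for lower toxicity in this test), compound 1 `CCO/N=C(/c1ccc(Br)cc1)C1CCN(C(C)(C)CCNC(=O)c2c(Cl)cncc2Cl)CC1` gives 34000 nM and compound 2 `CC(CCNC(=O)c1c(Cl)cncc1Cl)N1CCC(C(Oc2cccc(C(=O)O)n2)c2ccc(C(F)(F)F)cc2)CC1` gives 28700 nM so the two sit together within the usual scatter of repeated measurements. Compound 3 `CCO/N=C(/c1ccc(Br)cc1)C1CCN(C(C)CCNC(=O)c2c(C)cc[n+]([O-])c2C)CC1` is recorded as > 177000 nM and that entry is a limit of the assay, not a number.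

Compound 4 `CC(CCNC(=O)c1c(Cl)cncc1Cl)N1CCC(C(Oc2cccc(Cl)n2)c2ccc(C(F)(F)F)cc2)CC1` has not yet been measured. It departs from compound 2 in one place chloro in place of carboxy on an aromatic carbon and the change is chloro in place of carboxy on an aromatic carbon, next to the ring nitrogen and meta to a large group. Among the measured compounds shown here, no measured pair shows this swap on its own, so any forecast is loose. Compound 1 carries no carboxy group and gives 34000 nM in the same band as compound 2, which argues against a large shift. Compound 3 also has no carboxy group and goes against that reading with its limit. The expected step of a 1.4-fold lower number from compound 2 to compound 4 (0.16 log units; within the scatter) is small, leans toward a lower number and may not clear the scatter. For compound 4 the estimate in this assay is 20000 nM with an expected range of 7000 nM to 45000 nM at this stage.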

Compound 4, half-maximal cytotoxic concentration: > 32500 nM
Compound 4: no number, only a limit; the forecaster's own chance of this, stated with the estimate: 10%; middle value at least 1.6-fold (0.21 log units) from the limit.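

In this assay, among the compounds shown here, the change from 6-carboxypyridin-2-yl to 6-chloropyridin-2-yl gives the first reading of a single swap at this position: an at least 1.1-fold higher number from compound 2 to compound 4 (0.05 log units; that floor lies within the scatter). Compound 4 is recorded as a limit of the assay and not as a number, so this step is only a floor and its true size cannot be read: the limit of > 32500 nM in this assay, at which 1 of the 4 values shown sits. Even so, the pair shows that, on this core, putting chloro in place of carboxy on this aromatic carbon gives no sign of a lower number, which compound 1 and compound 3 could not show since they differ from compound 2 in more than one place.

From the compounds shown here alone, how far compound 4 lies beyond its limit remains open, and with it whether the swap has any real effect on this read-out or none that exceeds the scatter. The compounds shown also do not tell whether another group on this carbon, such as an amine or a methoxy group, would give a number close to that of compound 2.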